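Ring-isomer step on the sulfonyl sulfur

The compounds below may be only part of what the source reports. "The series", "measured", "known", "first", "only" and "open" are said of these compounds alone.

Measured so far in a functional assay on the whole organism (strain Jcl:Sprague-Dawley) for inhibition, with Rattus norvegicus as the target, with stated times of 3 min and 3 h, at a dose of 1 mg/kg by the intravenous route; a lower number here means less inhibition, a higher number more inhibition at the dose given (going by the name of the read-out):
compound 1 `CNCc1cn(S(=O)(=O)c2cccc(OC)n2)c(-c2cccnc2F)c1F`: 98%
compound 2 `CNCc1cn(S(=O)(=O)c2cnccc2C)c(-c2cccnc2F)c1F`: 98%

Among the compounds with values here, compound 2 stands level with compound 1, the only other measured member of the series: the step of no change at the digits printed from compound 1 to compound 2 (within the scatter) exchanged the group on the sulfonyl sulfur and left the read-out unchanged within the scatter. Within the data shown here, both compounds sit level with each other at the dose given, so the series so far gives no sign that the group on the sulfonyl sulfur moves this read-out.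

Compound 3 `CNCc1cn(S(=O)(=O)c2cncc(C)c2)c(-c2cccnc2F)c1F` is next. Its change from compound 2 is 5-methylpyridin-3-yl in place of 4-methylpyridin-3-yl on a sulfonyl sulfur; the two have the same atoms joined differently, the methyl moving to another position on the pyridinyl ring that sits on the sulfonyl sulfur. Among the measured compounds shown here, the one step that bears on this place, no change at the digits printed from compound 1 to compound 2 (within the scatter), was a larger exchange of the whole ring and produced no change beyond the scatter. On that basis the expected step of a number 2 percentage points lower from compound 2 to compound 3 (within the scatter) is none beyond the scatter, with the read-out already near its ceiling. Compound 3 is therefore estimated at 96%, in the range 86% to 100%.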

Compound 3, a percentage reported as inhibition, in the whole organism at one dose (the size of the read-out at that dose, not a potency) in the Rattus norvegicus assay: 87%
The estimate for compound 3 lay 9 percentage points above the measured number; measured number inside the range.
By their numbers in the Rattus norvegicus assay, from the lowest: compound 3; then compounds 1 and 2 (each within the scatter of the next).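

Moving the methyl on the pyridinyl ring on the sulfonyl sulfur, from 4-methylpyridin-3-yl to 5-methylpyridin-3-yl, gave in the Rattus norvegicus assay a number 11 percentage points lower from compound 2 to compound 3 (beyond the scatter) and so showed that this place can move the read-out, which the earlier exchange of the whole ring had not. The step of a number 11 percentage points lower from compound 1 to compound 3 (beyond the scatter) is of the same size, so of the three groups on the sulfonyl sulfur, 5-methylpyridin-3-yl alone stands apart, while 6-methoxypyridin-2-yl and 4-methylpyridin-3-yl remain level; the arrangement of the ring substituent therefore counts, not merely the exchange of one ring for another. In a physicochemical assay for lipophilicity, read by HPLC, at pH 7.4 (on this read-out lower numbers stand for lower lipophilicity and higher numbers for higher lipophilicity), compound 2 gives 0.43 and compound 3 gives 0.61, two values within the scatter of each other, and nothing on hand accounts for the difference in the whole-organism read-out.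

Open, as far as these compounds go, is whether the difference between the methyl isomers extends to other groups on this pyridinyl ring, such as an ethyl, a methoxy or a carboxylic acid. Also open, from the compounds shown here alone, is how a phenyl ring on the sulfonyl sulfur would compare in the Rattus norvegicus assay with the three pyridinyl groups.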